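The source may hold more compounds than are shown below. What is called first, only, known or untested is meant among the compounds shown, and "the series" means these compounds.

Measured so far:
- compound 1 `COc1cc(-c2nn(-c3cccc(NC(=O)c4ccc(Cl)c(C(F)(F)F)c4)c3)cc2-c2ccncc2)ccc1Cl` — 2050 nM
- compound 2 `COc1cc(-c2nn(-c3cccc(NC(=O)c4cccc(C(F)(F)F)c4)c3)cc2-c2ccncc2)ccc1Cl` — 2550 nM
- compound 3 `O=C(Nc1cccc(-n2cc(-c3ccncc3)c(-c3ccc(Cl)c(O)c3)n2)c1)Nc1cc(C(F)(F)F)cc(C(F)(F)F)c1` — 1820 nM

In a functional assay on T47D cells (Homo sapiens) for inhibition, read by sulforhodamine B assay, with a stated time of 48 h (a higher number here means a weaker inhibitor of growth, a lower number a stronger inhibitor of growth), compound 2 gives the highest of the three numbers, yet it sits within the scatter of both compound 1 and compound 3. Compound 4 `COc1cc(-c2nn(-c3cccc(NC(=O)Nc4cccc(C(F)(F)F)c4)c3)cc2-c2ccncc2)ccc1Cl` derives from compound 2 by (3-(trifluoromethyl)phenyl)amino in place of 3-(trifluoromethyl)phenyl on a carbonyl carbon. For the measured compounds named here, the only single-change step recorded, a 1.2-fold higher number from compound 1 to compound 2 (0.09 log units; within the scatter), concerns a different position and does not bear on this change. Compound 3 also carries an amino group on the carbonyl carbon, but it differs from compound 2 in more than one place, so its number gives no isolated reading of this change. No step beyond the scatter is therefore expected in this assay; the estimated step is a 1.3-fold lower number from compound 2 to compound 4 (0.11 log units; within the scatter). Compound 4 is estimated at 2000 nM, within 700 nM to 6000 nM.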

Compound 4, concentration for 50% growth inhibition: 1650 nM
Compound 4: middle estimate off by 1.2-fold (0.08 log units), on the high side, within the range that was stated.
By their numbers in this assay, from the lowest: compounds 4, 3, 1 and 2 (each within the scatter of the next).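

In this assay, the urea-type change on the carbonyl carbon can now be read in isolation: a 1.5-fold lower number from compound 2 to compound 4 (0.19 log units; within the scatter). The change from 4-chloro-3-(trifluoromethyl)phenyl to (3-(trifluoromethyl)phenyl)amino gives a 1.2-fold lower number from compound 1 to compound 4 (0.09 log units; within the scatter), so neither reading separates the entering group from the groups it replaces, even with the added nitrogen and its hydrogen-bond donor. No available evidence bears on this result. Still open, going by these compounds, is whether a morpholine or a simple alkylamine in place of (3-(trifluoromethyl)phenyl)amino on this carbonyl carbon would give a step beyond the scatter.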